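Cyclopropyl Ketone Swap Across Two Heteroaryl Cores

This account rests on a few compounds, and the source may have more. Where it says the series, first, only, none or still open, it means among the compounds named here.

Compound 1 `CC(=O)C1=C(C)NC(=O)NC1c1ccoc1` and compound 3 `CC(=O)C1=C(C)NC(=O)NC1c1ccsc1` share one core and differ only in the group on the saturated ring carbon: thiophen-3-yl in place of furan-3-yl on a saturated ring carbon. In an assay on membranes from HeLa cells for displacement of a labelled ligand from adenosine receptor A3 (Homo sapiens), read by scintillation counting, with a stated time of 180 min, tested at 1 uM (on this read-out lower numbers stand for less inhibition and higher numbers for more inhibition at the one concentration tested (going by the name of the read-out)), compound 1 gives 2% and compound 3 gives 1%; the step of a number 1 percentage points lower from compound 1 to compound 3 (within the scatter) means the two heteroaryl groups cannot be told apart on this read-out. Compound 2 `CC1=C(C(=O)C2CC2)C(c2ccoc2)NC(=O)N1` carries a larger ketone substituent on the core of compound 1: cyclopropyl in place of methyl on a carbonyl carbon. In this assay compound 2 gives 16%, and the step of a number 14 percentage points higher from compound 1 to compound 2 (beyond the scatter) is the only movement beyond the scatter among the three measured compounds.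

Compound 4 `CC1=C(C(=O)C2CC2)C(c2ccsc2)NC(=O)N1` has not yet been measured. It carries the same change on the core of compound 3, (cyclopropyl in place of methyl on a carbonyl carbon), and the surroundings of that place are described in the same words as for the pair of compound 1 and compound 2, so this is the same change. Given that the two cores give readings within the scatter of each other, the expected step is a number 14 percentage points higher from compound 3 to compound 4 (beyond the scatter), because the same change gave a number 14 percentage points higher from compound 1 to compound 2 (beyond the scatter). On that basis compound 4 is expected to give about 15% in this assay. Compound 4 is estimated to fall between 3% and 28%. This expectation rests on a single measured step, so it is held loosely.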

Compound 4, a percentage reported as inhibition, at one concentration (the size of the read-out at that concentration, not a potency): 1%
The estimate for compound 4 lay 14 percentage points above the measured number; measured number below the stated range.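

With cyclopropyl in place of methyl on a carbonyl carbon, this assay shows no change at the digits printed from compound 3 to compound 4 (within the scatter), so the step of a number 14 percentage points higher from compound 1 to compound 2 (beyond the scatter) did not reappear on the thiophen-3-yl core. This does not show that the change truly acts differently on the two cores, and it does not show that the change carries over either, as the two steps cannot be separated: the same change on two cores in this assay, a number 14 percentage points higher (beyond the scatter) from compound 1 to compound 2 and no change at the digits printed (within the scatter) from compound 3 to compound 4, 14 percentage points apart, within the scatter of two such steps. The same caution holds when the pairs are read the other way, with thiophen-3-yl in place of furan-3-yl, where the cyclopropylcarbonyl compounds give a number 15 percentage points lower from compound 2 to compound 4 (beyond the scatter) and the comparison with the acetyl compounds stays unresolved: the same change on two cores in this assay, a number 1 percentage points lower (within the scatter) from compound 1 to compound 3 and a number 15 percentage points lower (beyond the scatter) from compound 2 to compound 4, 14 percentage points apart, within the scatter of two such steps.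

The compounds shown leave open whether a cyclobutylcarbonyl or benzoyl group in place of acetyl would move the reading on either core, which would give more than one pair from which to judge whether the change carries over. They also leave open what a pyridine ring would do in place of the furan-3-yl or thiophen-3-yl group, and how any of these compounds would read at other concentrations.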